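This account rests on a few compounds, and the source may have more. Where it says the series, first, only, none or still open, it means among the compounds named here.

Of the compounds shown here, three of one shared core have been measured. In a functional assay on HCT-116 cells (Homo sapiens) for inhibition, read by MTT assay, with a stated time of 24 h, tested at 2.5 uM (on this read-out lower numbers stand for less inhibition of growth and higher numbers for more inhibition of growth at the one concentration tested), compound 1, with the structure `CS(=O)(=O)c1ccc(-c2cnc3[nH]cc(-c4nnc(-c5ccccc5)o4)c(=O)c3c2)cc1`, gives 0.53%. Compound 2, `O=c1c(-c2nnc(-c3ccc(F)cc3)o2)c[nH]c2ncc(-c3cccnc3)cc12`, gives 9.87% in this assay, and compound 3, `N#Cc1ccc(-c2cnc3[nH]cc(-c4nnc(-c5ccc(Cl)cc5)o4)c(=O)c3c2)cc1`, gives 13.7%. Compound 1 thus has the lowest of the three numbers; the gap to compound 2 lies within the usual scatter of such measurements, while the gap to compound 3 lies beyond it. All three numbers sit in a low range, so none of the compounds strongly held back the growth of these cells at the single concentration used.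

Compound 4, `CS(=O)(=O)c1ccc(-c2cnc3[nH]cc(-c4nnc(-c5cccnc5)o4)c(=O)c3c2)cc1`, is the next member of the set and has not yet been measured. It differs from compound 1 in one place: pyridin-3-yl in place of phenyl on an aromatic carbon. Going by the values given here, no pair of measured compounds differs by exactly this change, so no measured step guides the expectation. Since every measured number is low, a step of a number 4.5 percentage points higher from compound 1 to compound 4 (within the scatter) from compound 1 to compound 4 is expected, that is, no change beyond the scatter. Compound 4 is therefore estimated at 5%, most likely between 0% and 18%.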

Compound 4, percent growth inhibition at one concentration: 4.32%
Compound 4: middle estimate off by 0.7 percentage points, on the high side; the range from low to high includes it.
By their numbers in this assay, from the lowest: compounds 1, 4, 2 and 3 (each within the scatter of the next, the first and the last beyond it).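

In this assay, going by these compounds alone, putting pyridin-3-yl in place of phenyl on an aromatic carbon of the five-membered ring gives a number 3.8 percentage points higher from compound 1 to compound 4 (within the scatter), the first direct reading for a change at this position. A ring nitrogen, counted as one hydrogen-bond acceptor, can thus replace a ring carbon here with no change that this read-out can separate from ordinary scatter, and growth inhibition stays low. No measurement shown offers an explanation for this result.

The compounds shown leave open whether a quite different group at this position, such as an amine, a carboxylic acid or a longer alkyl chain, would move the number beyond the scatter. They also leave open whether the same swap would give a similar step with a different group elsewhere on the shared core.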